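This account rests on a few compounds, and the source may have more. Where it says the series, first, only, none or still open, it means among the compounds named here.

Compound 1 has the structure `Cc1ccc(NC(=O)COc2nc3ccccc3nc2C)cc1`. In an ADME assay on BEAS-2B cells (Homo sapiens) for inhibition, read by MTT assay, with a stated time of 24 h (on this read-out lower numbers stand for stronger inhibition and higher numbers for weaker inhibition), compound 1 gives > 100000 nM, a limit of the assay.
Compound 2 has the structure `Cc1nc2ccccc2nc1OCC(=O)Nc1ccc(Cl)cc1`. In this assay compound 2 gives > 100000 nM, also a limit.
Compound 3 has the structure `Cc1ccc(NC(=O)COc2nc3ccccc3nc2/C=C\c2ccncc2)cc1`. In this assay compound 3 gives > 100000 nM, again a limit.

Compound 3 therefore stands where every measured compound stands: at the upper limit of this assay, with no number of its own. All three measured values share this, as shown by the limit of > 100000 nM in this assay, at which 3 of the 3 values shown sit. The step from compound 3 to compound 4, whose structure is `O=C(COc1nc2ccccc2nc1/C=C\c1ccncc1)Nc1ccc(Cl)cc1`, is chloro in place of methyl on an aromatic carbon. The same exchange has been made once already among the measured compounds, as the step that the two limits leave unreadable from compound 1 to compound 2; both ends of that step sit at the limit, so its size cannot be read. The step that the two limits leave unreadable from compound 1 to compound 3 is likewise unreadable for the same reason. Among the measured compounds shown here, no measured step gives a readable size, so there is nothing to argue that swapping methyl for chloro moves the value in either direction beyond the scatter. The expectation for compound 4 is accordingly that it, too, comes out at or beyond the limit, an estimated step that the limit leaves unreadable from compound 3 to compound 4 that is nothing readable. Compound 4 is thus estimated at 150000 nM, within 50000 nM to 500000 nM.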

Compound 4, half-maximal inhibitory concentration: > 100000 nM
Compound 4 ended at the assay's limit; the forecaster's own chance of this, stated with the estimate: 85%; the middle value is on the limit's open side.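

Compound 4 sits at the assay's limit, as do compound 1, compound 2 and compound 3, so neither the step from compound 3 to compound 4 nor that from compound 2 to compound 4 can be read. The compounds shown leave open whether the methyl-to-chloro exchange or the 2-(pyridin-4-yl)ethenyl group changes anything in this assay, as no compound has a number of its own: the limit of > 100000 nM in this assay, at which 4 of the 4 values shown sit.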